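The source may hold more compounds than are shown below. What is called first, only, known or untested is meant among the compounds shown, and "the series" means these compounds.

In a functional assay on MDA-MB-231 cells (Homo sapiens) for inhibition, read by sulforhodamine B assay, with a stated time of 72 h (a lower number here means a stronger inhibitor of growth, a higher number a weaker inhibitor of growth), compound 2 `CCOC(=O)/C=C/c1ccncc1-c1ccc2c(ccn2C)c1` gives 10200 nM and compound 3 `CNC(=O)/C=C/c1ccncc1-c1ccc2c(ccn2C)c1` gives 8550 nM. Within the data shown here, these two stand level, with a 1.2-fold lower number from compound 2 to compound 3 (0.08 log units; within the scatter), so compound 3 has compound 2 as its only neighbour with a number. Compound 1 `CCOC(=O)/C=C/c1ccncc1-c1ccc2[nH]ccc2c1` gives > 10000 nM, which is a limit of this assay and not a number.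

Compound 4 `CNC(=O)/C=C/c1ccncc1-c1ccc2[nH]ccc2c1` differs from compound 3 by hydrogen in place of methyl on an aromatic nitrogen. Among the measured compounds shown here, the one measured step at this place runs the opposite way, and it gives neither size nor direction: a step that the limit leaves unreadable from compound 1 to compound 2. The other measured step, the change at the carbonyl carbon, stayed within the scatter. The values also sit close to the limit of > 10000 nM in this assay, at which 1 of the 3 values shown sits, so a report of a limit for compound 4 is a real possibility. No step beyond the scatter is expected, with at most a slight drift to a higher number. The estimated step is a 1.3-fold higher number from compound 3 to compound 4 (0.11 log units; within the scatter). The estimate for compound 4 is 11000 nM, with an expected range of 6000 nM to 20000 nM.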

Compound 4, concentration for 50% growth inhibition: > 10000 nM
Compound 4 ended at the assay's limit (the forecaster's own chance of this, stated with the estimate: 50%); the middle value lies beyond the limit too.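

In this assay, among these compounds, the change to hydrogen in place of methyl on an aromatic nitrogen now has a lower bound for the first time, an at least 1.1-fold higher number from compound 3 to compound 4 (0.06 log units; that floor lies within the scatter), but that floor does not establish a change beyond the scatter. Both compounds with hydrogen on this nitrogen, compound 1 and compound 4, end at a limit, whereas compound 2 and compound 3, both with methyl there, carry numbers; the steps from compound 1 cannot be read. Little room remains for reading further steps in this part of the series: the limit of > 10000 nM in this assay, at which 2 of the 4 values shown sit.

Going by these compounds, whether the methylamino amide and the ethyl ester truly match in the hydrogen pair stays open. Also open, on these data alone, is whether an ethyl or longer chain on this nitrogen, or a carboxylic acid at the carbonyl carbon, would give a number clearly below these.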